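From compound 2 to compound 3: working notes

The source may report more compounds than this note shows. Statements on the series, on what has been measured and on what is new or still open speak of the compounds shown alone.

Measured so far:
compound 1 `O=C(CCCCCCc1ccccc1)c1ncc(C(=O)C(F)(F)F)o1` — an assay on HEK-293T cells for inhibition of diacylglycerol lipase-alpha (Homo sapiens), read by colorimetric assay; on this read-out lower numbers stand for stronger inhibition and higher numbers for weaker inhibition: 1820 nM
compound 2 `COc1cnc(C(=O)CCCCCCc2ccccc2)o1` — this assay: > 10000 nM (a limit)

Compound 2 stands only at the limit of > 10000 nM in this assay, at which 1 of the 2 values shown sits; no number is known for it. Compound 3 `O=C(CCCCCCc1ccccc1)c1ncc(-c2ccc(F)cc2)o1` differs from compound 2 by 4-fluorophenyl in place of methoxy on an aromatic carbon. For the measured compounds named here, the one measured step, an at least 5.4-fold higher number from compound 1 to compound 2 (0.73 log units; beyond the scatter), changes the same aromatic carbon but says nothing about 4-fluorophenyl, so the expected step of an at least 1.4-fold lower number from compound 2 to compound 3 (0.15 log units; that floor lies within the scatter) is uncertain in direction. Compound 3 in this assay is estimated at 7000 nM, likely between 1500 nM and 30000 nM.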

Compound 3, half-maximal inhibitory concentration: > 10000 nM
Compound 3 ended at the assay's limit; the forecaster's own chance of this, stated with the estimate: 50%; middle value at least 1.4-fold (0.15 log units) away from the limit.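

In this assay, 4-fluorophenyl on this aromatic carbon gives an at least 5.4-fold higher number from compound 1 to compound 3 (0.73 log units; beyond the scatter), so a large aromatic replacement for (trifluoromethyl)carbonyl, like the small methoxy, leaves compound 1 as the only compound shown with a readable number. The two replacements therefore differ greatly in size without any readable recovery. Compound 2 and compound 3 both sit at a limit, and the step between them cannot be read: the limit of > 10000 nM in this assay, at which 2 of the 3 values shown sit.

Open, going by these compounds, is whether a nitrile, a carboxylic acid or an acetyl group on this carbon would give a readable number in this assay. On these data alone, how the methoxy and 4-fluorophenyl groups rank also stays open.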